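The source may hold more compounds than are shown below. What is called first, only, known or untested is meant among the compounds shown, and "the series" means these compounds.

Going by the values given here, compound 1, `COc1ccc(-c2cnc(NC(=O)C3CCNCC3)n2C)cc1`, is the first of the measured set. In a toxicity assay on THP-1 cells (Homo sapiens) for inhibition (on this read-out higher numbers stand for lower toxicity in this test and lower numbers for higher toxicity in this test), compound 1 gives > 100000 nM, which is a limit of the assay and not a number.
Compound 2, `COc1ccc(-c2cnc(NC(=O)c3ccno3)n2C)cc1`, is the second. In this assay compound 2 gives > 100000 nM, again a limit rather than a number.
Compound 3, `COc1ccc(-c2cnc(NC(C)=O)n2C)cc1`, is the third. In this assay compound 3 gives > 100000 nM, also a limit.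

Compound 3 therefore stands at the ceiling of what this assay reports, and it does not stand alone there: the evidence is the limit of > 100000 nM in this assay, at which 3 of the 3 values shown sit. The three measured steps, a step that the two limits leave unreadable from compound 1 to compound 2, a step that the two limits leave unreadable from compound 1 to compound 3 and a step that the two limits leave unreadable from compound 2 to compound 3, all change the group on the carbonyl carbon, yet none of them can be sized, since each joins two limits.

The step to compound 4, `COc1ccc(-c2cnc(NC(=O)c3ccccc3OC)n2C)cc1`, is of the same kind: 2-methoxyphenyl in place of methyl on a carbonyl carbon. Every measured exchange at this carbonyl carbon has left the read-out at the limit, so no step beyond the scatter is expected in this assay from that change. Compound 4 is accordingly expected to sit at the same ceiling, with a number no higher from compound 3 to compound 4 (the limit leaves the size open) as the estimated step. The estimate for compound 4 in this assay is 100000 nM, with a range from 40000 nM to 200000 nM, and most likely the assay will once more report only a limit.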

Compound 4, half-maximal cytotoxic concentration: > 100000 nM
Compound 4 ended at the assay's limit; the forecaster's own chance of this, stated with the estimate: 75%; the middle value lies on the limit itself.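

In this assay compound 4 gives > 100000 nM as a limit and not a number. Its steps from compound 1, compound 2 and compound 3 therefore cannot be read, as each joins two limits: the limit of > 100000 nM in this assay, at which 4 of the 4 values shown sit. The compounds shown leave open whether any group on the carbonyl carbon would bring a measurable number in this assay at all.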